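Replacing an aminophenyl group with a piperidine ring

The source may hold more compounds than are shown below. What is called first, only, known or untested is meant among the compounds shown, and "the series" means these compounds.

In a physicochemical assay for solubility, read by LC-MS, in phosphate buffer, measured as thermodynamic solubility, with a stated time of 24 h, at pH 7.4 (on this read-out higher numbers stand for higher solubility and lower numbers for lower solubility), compound 2 (`Cn1cc(-c2cnc3[nH]cc(-c4cccc(N)c4)c3c2)cn1`) reads 300000 nM and stands highest of three numbers. Compound 1 (`Cn1cc(-c2cnc3[nH]cc(-c4ccc(F)cc4)c3c2)cn1`) sits lower (at 9000 nM), and compound 3 (`Cn1cc(-c2cnc3[nH]cc(-c4cccc([N+](=O)[O-])c4)c3c2)cn1`) lower still (at 2000 nM). Compound 4 (`Cn1cc(-c2cnc3[nH]cc(C4CCCNC4)c3c2)cn1`), not yet measured, carries piperidin-3-yl in place of 3-aminophenyl (piperidin-3-yl in place of 3-aminophenyl on an aromatic carbon), so a non-aromatic ring with a hetero atom replaces an aromatic ring of carbon only. Two large measured steps show how far changes to this group can move the number (a 33-fold higher number from compound 1 to compound 2 (1.52 log units; beyond the scatter), and a 150-fold lower number from compound 2 to compound 3 (2.18 log units; beyond the scatter)). Neither exchanges an aromatic ring for a non-aromatic one, so neither sets a direction here. The expected step stays within the usual scatter (a 1.3-fold higher number from compound 2 to compound 4 (0.12 log units; within the scatter)). For compound 4 the estimate is 400000 nM (expected range 120000 nM to 1200000 nM).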

Compound 4, solubility: 1000000 nM
For compound 4 the middle estimate is 2.5-fold (0.40 log units) below the measured one, within the range that was stated.
By their numbers in this assay, from the lowest: compound 3; then compound 1; then compound 2; then compound 4.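

In this assay, a non-aromatic ring is accepted at this position on the five-membered aromatic ring, with a 3.3-fold higher number from compound 2 to compound 4 (0.52 log units; beyond the scatter) and a 110-fold higher number from compound 1 to compound 4 (2.05 log units; beyond the scatter) for the same exchange from the fluorinated compound. Among the compounds shown here, the earlier steps only swapped one aromatic ring for another or changed its substituent, so this is the first sign that an aromatic ring is not required here for a high number. No measurement at hand accounts for the rise.

Still open, from the compounds shown here alone, is whether the ring nitrogen must sit where it does in piperidin-3-yl, which piperidin-4-yl would test. An N-methylpiperidine or an open-chain aminopropyl group would show how much of the ring and its hydrogen-bond donor the number depends on.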